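The source may hold more compounds than are shown below. What is called first, only, known or untested is meant among the compounds shown, and "the series" means these compounds.

Measured compounds in the series:
compound 1 `NC/C=C/CN(Cc1nc2ccccc2[nH]1)C1CCCc2cccnc21` — in a functional assay on CEM-CCRF cells for antagonist activity at C-X-C chemokine receptor type 4 (Homo sapiens), read by calcium flux (on this read-out higher numbers stand for weaker inhibition and lower numbers for stronger inhibition), compound 1 gives 160 nM
compound 2 `NCCCCCN(Cc1nc2ccccc2[nH]1)C1CCCc2cccnc21` — in this assay compound 2 gives 514 nM
compound 3 `CNCCCCN(Cc1nc2ccccc2[nH]1)C1CCCc2cccnc21` — in this assay compound 3 gives 190 nM

Compound 3 stands second highest of the three numbers. Its nearest neighbour is compound 1, with a 1.2-fold higher number from compound 1 to compound 3 (0.07 log units; within the scatter), so the two cannot be told apart. Its furthest is compound 2, with a 2.7-fold lower number from compound 2 to compound 3 (0.43 log units; beyond the scatter).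

Compound 4 `NCCCC(=O)N(Cc1nc2ccccc2[nH]1)C1CCCc2cccnc21` has not yet been measured. The change from compound 3 is (3-aminopropyl)carbonyl in place of 4-(methylamino)butyl on an amine nitrogen. The side chain keeps its length but the amine nitrogen of the core becomes an amide nitrogen, and the terminal amine returns to a primary one, as in compound 2.

Within the data shown here, no measured step covers the carbonyl on this nitrogen. The steps that touch the chain are a 3.2-fold higher number from compound 1 to compound 2 (0.51 log units; beyond the scatter) and a 2.7-fold lower number from compound 2 to compound 3 (0.43 log units; beyond the scatter), both modest and pointing to compound 2, the primary-amine saturated chain, as the highest number. As far as these compounds go, compound 4 shares that primary terminal amine and adds the carbonyl, which is untested. A modest move toward a higher number in this assay is therefore expected, with wide uncertainty: a 3.2-fold higher number from compound 3 to compound 4 (0.50 log units; beyond the scatter) is the estimated step. For compound 4 the expected value is 600 nM, within 200 nM to 2500 nM.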

Compound 4, half-maximal inhibitory concentration: 3200 nM
Beside the measured number, compound 4's estimate is 5.3-fold (0.73 log units) below it; the measured number lies above the stated range.
By their numbers in this assay, from the lowest: compounds 1 and 3 (each within the scatter of the next); then compound 2; then compound 4.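

In this assay, the amine nitrogen that carries the side chain proves far less tolerant than the earlier chain changes suggested: (3-aminopropyl)carbonyl in place of 4-(methylamino)butyl gives a 17-fold higher number from compound 3 to compound 4 (1.23 log units; beyond the scatter), larger than any step among the earlier chains. The primary terminal amine does not account for this, since with a primary amine at the end of both chains, (3-aminopropyl)carbonyl in place of 5-aminopentyl still gives a 6.2-fold higher number from compound 2 to compound 4 (0.79 log units; beyond the scatter), and the comparison with the unsaturated chain gives a 20-fold higher number from compound 1 to compound 4 (1.30 log units; beyond the scatter), which leaves compound 4 with the highest number of the four. Nothing shown here speaks to the reason for this rise.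

As far as these compounds go, whether the rise follows from a carbonyl on this nitrogen in particular remains open, and a sulfonyl on the same nitrogen, or a carbonyl further along a chain that keeps the amine nitrogen of the core, would separate these readings. Also open, from the compounds shown here alone, is whether a methylamino end on the (3-aminopropyl)carbonyl chain would lower the number, as the saturated chains show with a 2.7-fold lower number from compound 2 to compound 3 (0.43 log units; beyond the scatter).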